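Working notes: a smaller aryl group on the shared core

A few compounds are considered here, and "the series" means these few. Any claim that something is new, unique, unknown or untested is made for them only; others in the source may bear on it.

In an ADME assay on HEK293 cells (Homo sapiens) for cytotoxicity, read by MTT assay, with a stated time of 48 h (a lower number here means a stronger inhibitor, a higher number a weaker inhibitor), compound 1 `COc1cc(/C=C2/S/C(=N/c3ccccc3)N(Cc3ccncc3)C2=O)ccc1O` reads 67400 nM and compound 2 `CCOc1cc(/C=C2/S/C(=N/c3ccccc3)N(Cc3ccncc3)C2=O)ccc1O` reads 46500 nM so the two stand level within the scatter. Among the measured compounds shown here, the one measured step of a 1.4-fold lower number from compound 1 to compound 2 (0.16 log units; within the scatter) is methyl in place of hydrogen on a saturated chain carbon bound to an oxygen on an aromatic ring and gives no separation between them.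

Compound 3 `O=C1/C(=C\c2cccc(O)c2)S/C(=N/c2ccccc2)N1Cc1ccncc1` carries a different change 3-hydroxyphenyl in place of 3-ethoxy-4-hydroxyphenyl on a double-bonded chain carbon bound to a double-bonded ring carbon with 3-hydroxyphenyl in place of 3-ethoxy-4-hydroxyphenyl on a double-bonded chain carbon bound to a double-bonded ring carbon. For the measured compounds named here, no measured compound carries 3-hydroxyphenyl, so the size of this change has no direct measure and the estimate stays wide.

Going by the values given here, with a 1.4-fold lower number from compound 1 to compound 2 (0.16 log units; within the scatter) as the only guide, no step beyond the scatter is expected in this assay and no direction is favoured. The expected step is a 1.2-fold higher number from compound 2 to compound 3 (0.07 log units; within the scatter) on present data. Compound 3 is estimated at 55000 nM within a range of 22000 nM to 130000 nM for now.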

Compound 3, half-maximal inhibitory concentration: 150000 nM
For compound 3 the middle estimate is 2.7-fold (0.44 log units) below the measured one, and the stated range ends below it.
By their numbers in this assay, from the lowest: compounds 2 and 1 (each within the scatter of the next); then compound 3.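

At the position on a double-bonded chain carbon bound to a double-bonded ring carbon, the aryl group registers in this assay: 3-hydroxyphenyl in place of 3-ethoxy-4-hydroxyphenyl gives a modest step (a 3.2-fold higher number from compound 2 to compound 3 (0.51 log units; beyond the scatter)), and 3-hydroxyphenyl in place of 4-hydroxy-3-methoxyphenyl gives another (a 2.2-fold higher number from compound 1 to compound 3 (0.35 log units; beyond the scatter)). Among the compounds shown here, both steps lie beyond the scatter and point towards a weaker inhibitor, whereas the change in the alkoxy chain seen earlier separated nothing, so the replacement of the whole aryl group is the first change here to separate compounds. No available data bear on why the number rises at this position.

Each step replaces the whole aryl group in a single change, so the compounds shown do not tell how much of the rise goes with the loss of the alkoxy group and how much with the different hydroxyl pattern. Unsubstituted phenyl, 3-methoxyphenyl or an aryl group carrying an amine or a carboxylic acid at this place remain open, as does whether any of them would fall outside the scatter of 3-hydroxyphenyl.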